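Replacing 1H-indol-4-yl: notes on the unbound share

The compounds below may be only part of what the source reports. "The series", "measured", "known", "first", "only" and "open" are said of these compounds alone.

Measured in (an ADME assay on blood (Rattus norvegicus, strain Wistar Han) for protein binding, read by LC-MS, using equilibrium dialysis; a lower number here means a smaller unbound share, a higher number a larger unbound share of the compound)
compound 1 `CNC(=O)c1cc(C(=O)NC2CC2)cn([C@H](C)c2ccccc2)c1=O` gives 0.27
compound 2 `CNC(=O)c1cc(C(=O)NC2CC2)cn(Cc2cccc3[nH]ccc23)c1=O` gives 0.18

Compound 2 (0.18) stands within the usual scatter of compound 1 (0.27), so these two values do not separate. Compound 3 `CNC(=O)c1cc(C(=O)NC2CC2)cn(Cc2cccc([C@@H](C)O)c2)c1=O` carries 3-(1-hydroxyethyl)phenyl in place of 1H-indol-4-yl on a saturated chain carbon bound to an aromatic nitrogen. For the measured compounds named here, no measured step covers this change, so only those two values offer any guide in (this assay). The estimated step (a 1.5-fold higher number from compound 2 to compound 3 (0.18 log units; within the scatter)) is small, toward a larger unbound share, and is not expected to clear the scatter. For compound 3 the estimate is 0.27 with an expected range from (0.16) to (0.45).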

Compound 3, unbound fraction: 0.48
Compound 3: middle estimate off by 1.8-fold (0.25 log units), on the low side, and the stated range ends below it.
By their numbers in this assay, from the lowest: compounds 2, 1 and 3 (each within the scatter of the next, the first and the last beyond it).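

With the same count of heavy atoms entering and leaving, the group on a saturated chain carbon bound to an aromatic nitrogen still shifts the unbound share in this assay with a 2.7-fold higher number from compound 2 to compound 3 (0.43 log units; beyond the scatter) and thus beyond the scatter. For the compounds shown here, this is the first separation seen at this position, toward a larger unbound share. Nothing at hand explains the step.

Open, on these data alone, is which part of 3-(1-hydroxyethyl)phenyl carries the step, including its defined stereocentre. Also open, as far as these compounds go, is how an amine or a carboxylic acid in place of the hydroxyl would read here.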